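The source may report more compounds than this note shows. Statements on the series, on what has been measured and on what is new or still open speak of the compounds shown alone.

Measured so far in a functional assay on OVCAR-8 cells (Homo sapiens) for inhibition, read by sulforhodamine B assay, with a stated time of 48 h; a higher number here means that more compound is tolerated, a lower number that less compound is tolerated:
- compound 1 `Cc1cc(O)cc(-c2nn(CC#N)cc2-c2ccnc(-c3ccc(Oc4ccccc4)cc3)c2)c1`: 21900 nM
- compound 2 `COc1cc(C)cc(-c2nn(CC#N)cc2-c2ccnc(-c3ccc(N(C)C)cc3)c2)c1`: > 100000 nM

Compound 2 in this assay gives only a limit, > 100000 nM, and no number. That limit, (the limit of > 100000 nM in this assay, at which 1 of the 2 values shown sits), sets the upper edge of what the two values shown can say. Compound 1 in this assay gives 21900 nM, a number well inside the measured range. The two compounds differ at more than one place, so their values are noted side by side without reading a step between them.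

The step that follows goes from compound 2 to compound 3 `Cc1cc(O)cc(-c2nn(CC#N)cc2-c2ccnc(-c3ccc(N(C)C)cc3)c2)c1`. The change is hydrogen in place of methyl on an oxygen on an aromatic ring. For the measured compounds named here, no measured pair tells this change on its own, so its size is open. Compound 1, which carries the hydroxy group, is the only hold the series gives for a hydroxy compound with a number.

The expectation for compound 3 is a step from compound 2 to compound 3 of an at least 2.5-fold lower number from compound 2 to compound 3 (0.39 log units; beyond the scatter), toward a lower number. Compound 3 is therefore estimated at 40000 nM, with a range of 10000 nM to 150000 nM, and the chance that this assay again returns only a limit is not small.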

Compound 3, concentration lethal to 50% of the cells: > 100000 nM
Compound 3: no number, only a limit; the forecaster's own chance of this, stated with the estimate: 40%; at least 2.5-fold (0.39 log units) between middle value and limit.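

In this assay compound 3 gives > 100000 nM, which is a limit and not a number. For the compounds shown here, the methoxy to hydroxy change from compound 2 cannot be read, and it has no measured size in either direction, because both of its ends rest on the same edge of the assay: the limit of > 100000 nM in this assay, at which 2 of the 3 values shown sit. With the 3-hydroxy-5-methylphenyl group held constant, dimethylamino in place of phenoxy on an aromatic carbon gives an at least 4.5-fold higher number from compound 1 to compound 3 (0.65 log units; beyond the scatter), the first readable step, and it shows that this exchange at the far end of the molecule moves the value by more than the scatter.

Still open, on these data alone, is whether methoxy and hydroxy differ at all on the oxygen on the aromatic ring, which would take a pair in which both compounds return a number, such as a methoxy partner of compound 1. Also open, as far as these compounds go, is whether the shift seen with phenoxy would carry over to other groups on that aromatic carbon, such as a benzyloxy group or a morpholine, since a single pair cannot separate the oxygen of phenoxy from its added ring.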